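A few compounds are considered here, and "the series" means these few. Any claim that something is new, unique, unknown or untested is made for them only; others in the source may bear on it.

Three compounds have been measured so far in a functional assay on the whole organism (strain Wistar) for inhibition, with Rattus norvegicus as the target, read by paw edema, with stated times of 30 min and 5 h, at a dose of 0.05 mmol/kg by the oral route; a higher number here means more inhibition at the dose given (going by the name of the read-out), a lower number less inhibition:
compound 1, `Cc1ccc(C2=NN(c3ccc(S(C)(=O)=O)cc3)C(=O)CC2)cc1`, gives 60.5%
compound 2, `COc1ccc(C2=NN(c3ccc(S(C)(=O)=O)cc3)C(=O)CC2)cc1`, gives 68.4%
compound 3, `CCc1ccc(C2=NN(c3ccc(S(C)(=O)=O)cc3)C(=O)CC2)cc1`, gives 65.7%

All three share one core and differ only in a single group on an aromatic carbon. In this assay the lowest of the three numbers belongs to compound 1, yet it is not set apart: the step of a number 5.2 percentage points higher from compound 1 to compound 3 (within the scatter) and the step of a number 7.9 percentage points higher from compound 1 to compound 2 (within the scatter) both lie within the scatter, as does a number 2.7 percentage points lower from compound 2 to compound 3 (within the scatter), so the three compounds cannot be told apart with confidence on these numbers.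

The unmeasured compound 4, `CS(=O)(=O)c1ccc(N2N=C(c3ccc(Cl)cc3)CCC2=O)cc1`, is reached from compound 1 by one change: chloro in place of methyl on an aromatic carbon. The three measured steps are the ones that bear on it, since each also exchanges one small group on that same aromatic carbon, and none of them moved the number beyond the scatter. A step of similar size, again within the scatter, is therefore expected in this assay for the change to chloro, with no direction that can be foreseen. Compound 4 is thus estimated at 64%, within a range from 50% to 78%, which amounts to an expected step of a number 3.5 percentage points higher from compound 1 to compound 4 (within the scatter).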

Compound 4, a percentage reported as inhibition, in the whole organism at one dose (the size of the read-out at that dose, not a potency): 36.8%
Estimate against measurement, compound 4: 27.2 percentage points above; the whole stated range lies above it.
By their numbers in this assay, from the lowest: compound 4; then compounds 1, 3 and 2 (each within the scatter of the next).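

At this position on the aromatic ring, the earlier exchanges among methyl, methoxy and ethyl gave no readable difference in this assay, which could suggest that the position accepts any small group. Chloro shows otherwise: a number 23.7 percentage points lower from compound 1 to compound 4 (beyond the scatter) and a number 28.9 percentage points lower from compound 3 to compound 4 (beyond the scatter) and also a number 31.6 percentage points lower from compound 2 to compound 4 (beyond the scatter) all stand out, so compound 4 is set apart from the other three, and the identity of this single group can matter to the effect in the whole animal. Methyl and chloro each count 1 heavy atom, no ring and no hydrogen-bond donors or acceptors, so these counts do not separate the two groups, and nothing available explains the drop.

As far as these compounds go, whether the lower number belongs to chloro alone or would also appear with fluoro or bromo remains open, as does the reading for a trifluoromethyl group or a plain hydrogen at the same place. These numbers also come from a single oral dose, so they leave open whether compound 4 would catch up with the others at a higher dose.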